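This account rests on a few compounds, and the source may have more. Where it says the series, first, only, none or still open, it means among the compounds named here.

Working notes on the series. Compound 1 `Cc1cccc(-c2noc(C3CC(=O)N(c4ccc(C)c(Cl)c4)C3)n2)c1` gives 240 nM in an in vitro functional assay on HEK293-A cells for positive allosteric modulation of metabotropic glutamate receptor 5 (Homo sapiens), read by FLIPR and calcium flux (on this read-out lower numbers stand for an effect already at smaller amounts and higher numbers for an effect only at larger amounts of compound), and compound 3 `Cc1cccc(-c2noc(C3CC(=O)N(c4ccc(Cl)cc4)C3)n2)c1` gives 170 nM; the step of a 1.4-fold lower number from compound 1 to compound 3 (0.15 log units; within the scatter) concerns only the group on the amide-type nitrogen. Compound 2 `Cc1cccc(N2CC(c3nc(-c4cccc(Cl)c4)no3)CC2=O)c1` stands apart from both. In this assay compound 2 gives > 10000 nM, which is a limit of the assay and not a number, the single such result among the three (the limit of > 10000 nM in this assay, at which 1 of the 3 values shown sits). Compound 4 `COc1cccc(N2CC(c3nc(-c4cccc(Cl)c4)no3)CC2=O)c1` differs from compound 2 by methoxy in place of methyl on an aromatic carbon. Among the compounds with values here, no measured step touches this position; the one measured step, a 1.4-fold lower number from compound 1 to compound 3 (0.15 log units; within the scatter), lies elsewhere and within the scatter, so it offers no direction for this change. Starting from a limit, compound 4 is expected to remain near that limit, with an estimated 15000 nM in this assay, ranging from 3000 nM to 50000 nM. The expected step is therefore a step that the limit leaves unreadable from compound 2 to compound 4, with a high chance that only a limit is again reported.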

Compound 4, half-maximal effective concentration: > 10000 nM
Compound 4 was reported as a limit (the forecaster's own chance of this, stated with the estimate: 75%); the middle value does not contradict the limit.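

Compound 2 and compound 4 both sit at a limit of the assay, so no step between them can be read: the limit of > 10000 nM in this assay, at which 2 of the 4 values shown sit.

The compounds shown leave open whether methoxy in place of methyl changes the read-out at all.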